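Sulfonamide series: replacing the aryl group on the ring nitrogen

This account rests on a few compounds, and the source may have more. Where it says the series, first, only, none or still open, it means among the compounds named here.

Measured in a functional assay on A549 cells (Homo sapiens) for antiproliferative activity, read by MTT assay, with a stated time of 72 h; a lower number here means a stronger inhibitor, a higher number a weaker inhibitor:
compound 1 `COc1ncc(-c2ccc3c(c2)N(c2ccc(C)cc2)C(=O)CO3)cc1NS(=O)(=O)c1ccc(F)cc1`: 5870 nM
compound 2 `COc1cccc(N2C(=O)COc3ccc(-c4cnc(Cl)c(NS(=O)(=O)c5ccc(F)cc5)c4)cc32)c1`: 32700 nM

Of the two measured compounds, compound 2 has the higher number at 32700 nM, and the gap to compound 1 lies beyond the scatter. These two compounds differ in more than one place, so their gap isolates no single change.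

Compound 3 `O=C1COc2ccc(-c3cnc(Cl)c(NS(=O)(=O)c4ccc(F)cc4)c3)cc2N1C1CCCCC1` is the next compound to be read in this assay. It keeps the core of compound 2 and carries cyclohexyl in place of 3-methoxyphenyl on an amide-type nitrogen in a ring.

Going by the values given here, no measured step covers this change, so the expectation rests on little. A modest step towards a lower number is expected, and a step within the scatter would be no surprise. Among the compounds with values here, the only support is that compound 2 gives 32700 nM, while the one other number, for compound 1, is 5870 nM. The estimated step is a 1.8-fold lower number from compound 2 to compound 3 (0.26 log units; within the scatter). For compound 3 the estimated value is 18000 nM, with an expected range of 6000 nM to 50000 nM.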

Compound 3, half-maximal inhibitory concentration: 37900 nM
Beside the measured number, compound 3's estimate is 2.1-fold (0.32 log units) below it; measured number inside the range.
By their numbers in this assay, from the lowest: compound 1; then compounds 2 and 3 (each within the scatter of the next).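

In this assay, the series gains its first comparison that differs in one place, and it shows a 1.2-fold higher number from compound 2 to compound 3 (0.06 log units; within the scatter) when cyclohexyl takes the place of 3-methoxyphenyl on the amide-type nitrogen in a ring. With the rest of compound 2 kept, exchanging a six-membered aromatic ring for a six-membered non-aromatic ring, and giving up the hydrogen-bond acceptor of the leaving group, therefore leaves the reading within the scatter, and neither feature is shown to matter for this read-out on this core. No measurement on hand gives a reason for this flat step or says what the nitrogen substituent does in these cells.

Compound 1 differs from compound 2 and compound 3 in more than one place, so its gaps to them cannot be read as single changes, and what the aryl group on the ring nitrogen contributes when the rest of compound 1 is kept stays unresolved. On these data alone, it is also open whether a group of another kind on this nitrogen, such as a short ethyl chain, a chain ending in an amine or one ending in a carboxylic acid, would move the number beyond the scatter.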